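Varying the amide on a naphthyl-pyridine acrylamide core

The source may report more compounds than this note shows. Statements on the series, on what has been measured and on what is new or still open speak of the compounds shown alone.

Measured compounds:
compound 1 `CCOC(=O)/C=C/c1ccncc1-c1ccc2ccccc2c1`: 53.3 nM
compound 2 `CNC(=O)CCc1ccncc1-c1ccc2ccccc2c1`: 21.1 nM
compound 3 `COC1CN(C(=O)/C=C/c2ccncc2-c2ccc3ccccc3c2)C1`: 42.8 nM

Of the compounds shown here, three share the same core and have been tested in an assay on a protein complex for inhibition of CDK8/Cyclin C (Homo sapiens), with a stated time of 1 h; a higher number here means a weaker inhibitor, a lower number a stronger inhibitor. Compound 1 gives 53.3 nM in this assay, compound 2 gives 21.1 nM, and compound 3 gives 42.8 nM. Compound 3 stands second highest of the three numbers; its nearest neighbour is compound 1, from which it differs by a 1.2-fold lower number from compound 1 to compound 3 (0.10 log units; within the scatter), while compound 2 lies further off, with the lower number of the two.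

The next compound, compound 4 `NC(=O)/C=C/c1ccncc1-c1ccc2ccccc2c1`, has not yet been measured. It differs from compound 3 in one place: amino in place of 3-methoxyazetidin-1-yl on a carbonyl carbon. The step that bears most directly on this change is the one at the same carbonyl carbon, a 1.2-fold lower number from compound 1 to compound 3 (0.10 log units; within the scatter), which suggests that swapping the group on that carbonyl has little effect. The other step, a 2.5-fold lower number from compound 1 to compound 2 (0.40 log units; beyond the scatter), touches a different part of the side chain and is only loosely related.

Compound 4 is therefore expected to land close to compound 3, with a 1.4-fold lower number from compound 3 to compound 4 (0.15 log units; within the scatter) as the expected step. The estimate for compound 4 is 30 nM, with a range from 12 nM to 75 nM.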

Compound 4, half-maximal inhibitory concentration: 10.5 nM
Beside the measured number, compound 4's estimate is 2.9-fold (0.46 log units) above it; measured number below the stated range.
By their numbers in this assay, from the lowest: compounds 4 and 2 (each within the scatter of the next); then compounds 3 and 1 (each within the scatter of the next).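

Going by these compounds alone, at the carbonyl carbon, the identity of the group matters more than the earlier compounds suggested: in this assay, ethoxy and 3-methoxyazetidin-1-yl could not be told apart (a 1.2-fold lower number from compound 1 to compound 3 (0.10 log units; within the scatter)), whereas amino stands clear of both (a 4.1-fold lower number from compound 3 to compound 4 (0.61 log units; beyond the scatter); a 5.1-fold lower number from compound 1 to compound 4 (0.71 log units; beyond the scatter)), with each of these two steps beyond the scatter. Of the groups compared directly in this change, amino is the smaller and has no ring, and it counts a hydrogen-bond donor where 3-methoxyazetidin-1-yl counts none, so size, the ring and the donor all change together in this single step. On the aromatic carbon, 2-carbamoylethenyl and 2-(methylcarbamoyl)ethyl remain within the scatter of each other (a 2.0-fold lower number from compound 2 to compound 4 (0.30 log units; within the scatter)), which means that the side chains of these two compounds cannot be separated in this assay.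

Nothing measured here accounts for the difference that amino makes. Going by these compounds, it remains open whether methylamino or dimethylamino on the same carbonyl of the ethenyl chain would stay with amino or fall back towards 3-methoxyazetidin-1-yl, and whether a 2-carbamoylethyl chain or a carboxylic acid would fit the same picture.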